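The compounds below may be only part of what the source reports. "The series", "measured", "known", "first", "only" and "open" are said of these compounds alone.

Measured compounds:
compound 1, `O=C1O/C(=C\Cn2cc(-c3ccc(Br)cc3)nn2)C(OCc2ccccc2)=C1OCc1ccccc1`: in a functional assay on HCT-116 cells (Homo sapiens) for antiproliferative activity, read by MTT assay, with a stated time of 72 h (on this read-out higher numbers stand for weaker inhibition and lower numbers for stronger inhibition), compound 1 gives > 100000 nM
compound 2, `O=C1O[C@H]([C@@H](O)Cn2cc(-c3ccc(Br)cc3)nn2)C(OCc2ccccc2)=C1OCc1ccccc1`: in this assay compound 2 gives 9420 nM
compound 3, `O=C1O[C@H]([C@@H](O)Cn2cc(-c3cc(C(F)(F)F)cc(C(F)(F)F)c3)nn2)C(OCc2ccccc2)=C1OCc1ccccc1`: in this assay compound 3 gives 57200 nM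

Compound 1 stands at the edge of what was measured. Its value in this assay is a limit of the assay and not a number, as the limit of > 100000 nM in this assay, at which 1 of the 3 values shown sits, records. Compound 2 and compound 3, which share the dibenzyloxy lactone core but carry a hydroxyl on the side chain, do give numbers, and their values are the only ones in the set that do.

Compound 4, `Cc1ccc(-c2cn(C/C=C3\OC(=O)C(OCc4ccccc4)=C3OCc3ccccc3)nn2)cc1`, is the unmeasured compound. It differs from compound 1 in one place: methyl in place of bromo on an aromatic carbon. Going by the values given here, no measured pair shows this exchange, and no measured pair shows the exocyclic alkene of compound 1 alongside any other change, so nothing indicates how large a step to expect or in which direction. The expectation is that compound 4 stays near the limit at which compound 1 sits, with a step of a number no higher from compound 1 to compound 4 (the limit leaves the size open) that is expected to be no more than the scatter. Compound 4 is therefore estimated at 100000 nM, within 30000 nM to 300000 nM, and the assay is expected, more often than not, to report only a limit for it.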

Compound 4, half-maximal inhibitory concentration: > 100000 nM
Compound 4: no number, only a limit (the forecaster's own chance of this, stated with the estimate: 70%); the middle value sits exactly at the limit.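

In this assay compound 4 gives > 100000 nM and this is a limit of the assay, not a number. Compound 1 also stands at a limit, so no step between compound 1 and compound 4 can be read: the limit of > 100000 nM in this assay, at which 2 of the 4 values shown sit.

The compounds shown leave open what methyl in place of bromo does in a compound that gives a number in this assay.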